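Aryl swap on the enone chain: compound 4 outlook

The source may report more compounds than this note shows. Statements on the series, on what has been measured and on what is new or still open speak of the compounds shown alone.

Measured so far:
compound 1, `Cc1ccc(S(=O)(=O)/C(=C/c2ccc(C)s2)C(=O)c2ccc(Cl)cc2)cc1`, 50000 nM
compound 2, `Cc1ccc(S(=O)(=O)/C(=C/c2ccc(Cl)cc2)C(=O)c2ccc(Cl)cc2)cc1`, 1000 nM
compound 3, `Cc1ccc(/C=C(/SCc2ccc(F)cc2)C(=O)c2ccc(Cl)cc2)s1`, reported only as a limit: > 100000 nM

In a functional assay on DU-145 cells (Homo sapiens) for inhibition, read by trypan blue exclusion, with a stated time of 96 h (a higher number here means a weaker inhibitor of growth, a lower number a stronger inhibitor of growth), compound 1 gives 50000 nM and compound 2 gives 1000 nM. The step between them is a 50-fold lower number from compound 1 to compound 2 (1.70 log units; beyond the scatter); the change behind it is 4-chlorophenyl in place of 5-methylthiophen-2-yl on a double-bonded chain carbon bound to a double-bonded chain carbon. For compound 3 this assay reports only a limit, > 100000 nM. How the core of compound 3 differs from the core of compound 1 is not broken down here.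

Compound 4, `O=C(/C(=C\c1ccc(Cl)cc1)SCc1ccc(F)cc1)c1ccc(Cl)cc1`, is not yet measured. It differs from compound 3 by 4-chlorophenyl in place of 5-methylthiophen-2-yl on a double-bonded chain carbon bound to a double-bonded chain carbon, the same change that occurs between the two measured compounds, and the change occurs twice in this set.

From compound 3, whose value is a limit, the estimated step is an at least 20-fold lower number from compound 3 to compound 4 (1.30 log units; beyond the scatter), resting on a 50-fold lower number from compound 1 to compound 2 (1.70 log units; beyond the scatter). Compound 4 is thus expected at 5000 nM, with the estimate spanning 1000 nM to 50000 nM.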

Compound 4, concentration for 50% growth inhibition: 10000 nM
For compound 4 the middle estimate is 2.0-fold (0.30 log units) below the measured one; low and high end bracket the measured number.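

In this assay, 4-chlorophenyl in place of 5-methylthiophen-2-yl again gives a lower number on the second core, with an at least 10-fold lower number from compound 3 to compound 4 (1.00 log units; beyond the scatter). The direction of the change therefore carries over from the core of compound 1 to the core of compound 3, but whether its size does remains unsettled: the same change on two cores in this assay, a 50-fold lower number (1.70 log units; beyond the scatter) from compound 1 to compound 2 and an at least 10-fold lower number (1.00 log units; beyond the scatter) from compound 3 to compound 4; the limit leaves it open whether they differ. Compound 3 is a limit and not a number, so the step on its core has no upper bound: the limit of > 100000 nM in this assay, at which 1 of the 4 values shown sits.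

Open, going by these compounds, is whether a group other than 4-chlorophenyl in the same place, such as an amine or a longer chain, would follow the same direction. Two cores also give no basis for a rule across the wider series.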